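A few compounds are considered here, and "the series" means these few. Any claim that something is new, unique, unknown or untested is made for them only; others in the source may bear on it.

Values in a functional assay on A549 cells (Homo sapiens) for antiproliferative activity, read by MTT assay, with a stated time of 72 h; on this read-out higher numbers stand for weaker inhibition and lower numbers for stronger inhibition:
Compound 1 `COc1cc2c(Nc3ccc(C#N)cc3)ncnc2cc1OCCCN(C)Cc1ccccc1`: > 100000 nM (a limit)
Compound 2 `COc1cc2c(Nc3ccc(C#N)cc3)ncnc2cc1OCCCN1CCCC1`: 21800 nM
Compound 3 `COc1cc2c(Nc3ccc(C#N)cc3)ncnc2cc1OCCCN1CCCCC1CCO`: > 100000 nM (a limit)

Compound 3 has no number and stands with compound 1 at the limit of > 100000 nM in this assay, at which 2 of the 3 values shown sit. Compound 4 `COc1cc2c(Nc3ccc(C#N)cc3)ncnc2cc1OCCCN1CCC(N(C)C)CC1` is the next member: 4-(dimethylamino)piperidin-1-yl in place of 2-(2-hydroxyethyl)piperidin-1-yl on a saturated chain carbon, three bonds along the chain from an oxygen on an aromatic ring. The change lies on a saturated chain carbon, three bonds along the chain from an oxygen on an aromatic ring.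

Two readable steps at this place bear on it: an at least 4.5-fold lower number from compound 1 to compound 2 (0.66 log units; beyond the scatter) and an at least 4.5-fold higher number from compound 2 to compound 3 (0.66 log units; beyond the scatter). Neither involves the entering group, so the guide is loose. Compound 2 at 21800 nM is the only numeric anchor. For compound 4 a lower number than the limit of compound 3 is expected, at least a modest step, although another reading at the limit remains possible.

The expected step is an at least 4.0-fold lower number from compound 3 to compound 4 (0.60 log units; beyond the scatter).

For compound 4 the estimated value is 25000 nM, with an expected range of 7000 nM to 90000 nM.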

Compound 4, half-maximal inhibitory concentration: 42400 nM
For compound 4 the middle estimate is 1.7-fold (0.23 log units) below the measured one, within the range that was stated.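

In this assay, 4-(dimethylamino)piperidin-1-yl gives a second numeric value at this position, with an at least 2.3-fold lower number from compound 3 to compound 4 (0.37 log units; beyond the scatter) and an at least 2.3-fold lower number from compound 1 to compound 4 (0.37 log units; beyond the scatter), both sizes bounded on one side only. Against pyrrolidin-1-yl the result is a 1.9-fold higher number from compound 2 to compound 4 (0.29 log units; within the scatter), so these two groups are not separated in this assay. The other two compounds remain at a limit, not a number: the limit of > 100000 nM in this assay, at which 2 of the 4 values shown sit.

On these data alone, it remains open whether a morpholin-4-yl or 4-methylpiperazin-1-yl group at this position would separate from compound 2 and compound 4. As far as these compounds go, the effect of a shorter chain carrying pyrrolidin-1-yl is also open.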